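Replacing a Dihydroxyethyl Chain with Nonyl on a Guanine-Like Core

The source may report more compounds than this note shows. Statements on the series, on what has been measured and on what is new or still open speak of the compounds shown alone.

Compound 1 `Nc1nc(O)c2c(n1)n(C1OC(CO)[C@@H](O)[C@H]1O)c(=O)n2CC(O)CO`: 136%
Compound 2 `Cn1c(=O)n2c3c1c(=O)nc(N)n3CC1OC2[C@H](O)[C@@H]1O`: 9%
Compound 3 `C=CCn1c(=O)n(C2C[C@H](O)C(CO)O2)c2nc(N)nc(O)c21`: 99%

In a functional assay on the whole organism (B cells) with Mus musculus as the target (on this read-out higher numbers stand for larger maximal responses and lower numbers for smaller maximal responses), compound 1 gives 136%, the highest of the three numbers. Compound 3 comes nearest, and its value lies beyond the usual scatter below that of compound 1; compound 2, with 9%, lies far lower still. Compound 4 `CCCCCCCCCCn1c(=O)n(C2OC(CO)[C@@H](O)[C@H]2O)c2nc(N)nc(O)c21` is the unmeasured analogue of compound 1. It differs by nonyl in place of 1,2-dihydroxyethyl on a saturated chain carbon bound to an aromatic nitrogen. Among the measured compounds shown here, no pair of measured compounds that differ in only one place is available, so the size of this change cannot be read from the data. A moderate decrease is expected, as the step from compound 1 to compound 4 is estimated at a number 46 percentage points lower from compound 1 to compound 4 (beyond the scatter). Compound 4 is therefore expected to give 90%, with a range from 30% to 160%.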

Compound 4, largest response reached (reported as maximal response), in percent of the reference or control that the assay uses: 0%
Beside the measured number, compound 4's estimate is 90 percentage points above it, outside the stated range (below it).
By their numbers in this assay, from the lowest: compounds 4 and 2 (each within the scatter of the next); then compound 3; then compound 1.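

In this assay, among the compounds shown here, nonyl in place of 1,2-dihydroxyethyl on a saturated chain carbon bound to an aromatic nitrogen gives a number 136 percentage points lower from compound 1 to compound 4 (beyond the scatter), the first single-place change that can be read here. It shows that the response depends strongly on the chain at this position. Nothing available explains this drop. On these data alone, whether it follows the length of the chain or the absence of hydroxyl groups stays open: a butyl chain, or a nonyl chain ending in a hydroxyl group or an amine, would separate the two.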